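The source may report more compounds than this note shows. Statements on the series, on what has been measured and on what is new or still open speak of the compounds shown alone.

The study compares four compounds in a functional assay on A549 cells (Homo sapiens) for cytotoxicity, read by MTT assay, with a stated time of 6 days; a lower number here means that less compound is needed, a higher number that more compound is needed for the effect. Compound 1 `COC(=O)c1c(-c2ccc([N+](=O)[O-])cc2)oc2ccccc2c1=O` carries a methyl ester on its core. In this assay compound 1 gives no number but only a limit, > 25 ug/mL. Compound 2 `O=C(O)c1c(-c2ccc([N+](=O)[O-])cc2)oc2ccccc2c1=O` is the corresponding acid. In this assay compound 2 likewise reaches only a limit, > 25 ug/mL. The change from compound 2 to compound 1 is methyl in place of hydrogen on an oxygen next to a carbonyl group, and the step it made, a step that the two limits leave unreadable from compound 2 to compound 1, cannot be sized because the limit of > 25 ug/mL in this assay, at which 3 of the 3 values shown sit, holds both of its values.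

Compound 3 `COc1cc(-c2cc(=O)c3ccc(O)cc3o2)cc(OC)c1OC` rests on a different core; the difference between the two cores is not broken down here. In this assay compound 3 also stops at a limit, > 25 ug/mL. Compound 4 `COc1ccc2c(=O)cc(-c3cc(OC)c(OC)c(OC)c3)oc2c1` has not yet been measured. It differs from compound 3 by methyl in place of hydrogen on an oxygen on an aromatic ring. This is the same kind of change as that between compound 2 and compound 1, but not the same: there the oxygen is next to a carbonyl group with a carbonyl carbon as its other neighbour, here it is on an aromatic ring with an aromatic carbon as its other neighbour.

The step expected from this change is a step that the limit leaves unreadable from compound 3 to compound 4, a small one, because a step that the two limits leave unreadable from compound 2 to compound 1 gave no readable size and the three measured values all sit at the same limit. Compound 4 is therefore estimated at 40 ug/mL, within a range from 15 ug/mL to 150 ug/mL, and most probably again only a limit will be reported.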

Compound 4, concentration for half-maximal effect: > 25 ug/mL
Compound 4: a limit, no number; the forecaster's own chance of this, stated with the estimate: 75%; the middle value is on the limit's open side.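

In this assay compound 4 gives only a limit, > 25 ug/mL. The step between compound 3 and compound 4 therefore cannot be read, because all the compounds rest at the same limit: the limit of > 25 ug/mL in this assay, at which 4 of the 4 values shown sit.

The compounds shown leave open whether either methyl change, or the difference between the two cores, alters the result in this assay at all, and none of them gives a number.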